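The compounds below may be only part of what the source reports. "The series", "measured", "known", "first", "only" and "open" are said of these compounds alone.

Measured so far:
compound 1, `C=CC1=C(C(=O)NCc2ccc(C)cc2)C(c2ccc(F)cc2)OC1`: 62100 nM
compound 2, `C=CC1=C(C(=O)NCC(C)C)C(c2ccc(Cl)c(Cl)c2)OC1`: > 100000 nM

Both readings come from a functional assay on QGY7701 cells (Homo sapiens) for cytotoxicity, read by MTT assay, with a stated time of 24 h; a lower number here means a stronger inhibitor, a higher number a weaker inhibitor. In this assay, for the measured compounds named here, compound 1 gives 62100 nM, a weak result and the only actual number in the set. Compound 2 gives > 100000 nM, which is a limit of the assay rather than a number. The set therefore holds (the limit of > 100000 nM in this assay, at which 1 of the 2 values shown sits), and compound 1 stands as the single measured point, with nothing shown to place it higher or lower than a neighbour.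

Compound 3, `C=CC1=C(C(=O)Nc2cccc(C)c2)C(c2ccc(F)cc2)OC1`, has not yet been measured. It differs from compound 1 in one place: 3-methylphenyl in place of 4-methylbenzyl on an amide-type nitrogen. The rest of the shared core, with its vinyl group, its ring oxygen and its fluorinated aryl group, is unchanged.

Going by the values given here, no measured pair differs in a single place, so no measured step shows how such a swap plays out here. Among the compounds with values here, the only guide is compound 1 itself, already weak, and the expectation is a step of no size beyond the usual scatter in this assay, in no set direction.

Compound 3 is expected to give 60000 nM in this assay, with a likely range from 20000 nM to 180000 nM. That estimate means an expected step of a 1.0-fold lower number from compound 1 to compound 3 (0.01 log units; within the scatter), within the scatter.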

Compound 3, half-maximal inhibitory concentration: 56400 nM
Estimate against measurement, compound 3: 1.1-fold (0.03 log units) above, within the range that was stated.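

In this assay, for the compounds shown here, putting 3-methylphenyl in place of 4-methylbenzyl on the amide-type nitrogen gives a 1.1-fold lower number from compound 1 to compound 3 (0.04 log units; within the scatter), and this is the first single change in the set that can be read at all. The group that leaves has 8 heavy atoms and the group that enters has 7, each with one six-membered aromatic ring of carbon only, yet the two readings cannot be told apart. At this position, then, exchanging one of these methyl-bearing aromatic groups for the other does nothing measurable here, and both compounds remain weak.

Going by these compounds alone, whether a group of a different kind on that nitrogen, such as a carboxylic acid, an amine or a longer chain ending in a hydroxyl group, would give a clearly different number remains open, since this one step covers only two closely related aromatic groups. Compound 2 differs from compound 1 in more than one place and its reading is a limit of the assay, so no step to it can be read: the limit of > 100000 nM in this assay, at which 1 of the 3 values shown sits.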